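A Tail Amine Swap With No Direct Precedent

The source may hold more compounds than are shown below. What is called first, only, known or untested is meant among the compounds shown, and "the series" means these compounds.

Compound 1 `COc1cc2c(Oc3ccc(NC(=O)c4nn(-c5cccc(F)c5)c(=O)c5ccccc45)cc3F)ccnc2cc1OCCCN1CCCC1`: 190 nM
Compound 2 `COc1cc2c(Oc3ccc(NC(=O)c4nn(-c5ccc([N+](=O)[O-])cc5)c(=O)c5ccccc45)cc3F)ccnc2cc1OCCCN1CCCC1`: 1240 nM

Within the data shown here, in a functional assay on NCI-H460 cells (Homo sapiens) for cytotoxicity, read by MTT assay, with a stated time of 72 h (a lower number here means a stronger inhibitor, a higher number a weaker inhibitor), compound 1 has the lowest of the two numbers, and its only neighbour is compound 2, reached by a 6.5-fold higher number from compound 1 to compound 2 (0.81 log units; beyond the scatter). Compound 3 `COc1cc2c(Oc3ccc(NC(=O)c4nn(-c5cccc(F)c5)c(=O)c5ccccc45)cc3F)ccnc2cc1OCCCN1CCC(C)CC1` differs from compound 1 by 4-methylpiperidin-1-yl in place of pyrrolidin-1-yl on a saturated chain carbon, three bonds along the chain from an oxygen on an aromatic ring. Among the measured compounds shown here, the single measured step alters a different part of the molecule, the group on the aromatic nitrogen, so no measured step bears on this change. Nothing beyond the scatter is therefore expected. Compound 3 is estimated at 190 nM, between 70 nM and 520 nM. This expected step reads no change at the digits printed from compound 1 to compound 3 (within the scatter).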

Compound 3, half-maximal inhibitory concentration: 190 nM
Compound 3: middle estimate and measured number agree at the digits printed; measured number inside the range.
By their numbers in this assay, from the lowest: compounds 1 and 3 (each within the scatter of the next); then compound 2.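

In this assay, replacing pyrrolidin-1-yl with 4-methylpiperidin-1-yl gives no change at the digits printed from compound 1 to compound 3 (within the scatter), so the two compounds read alike. Among these compounds, this is the first measured look at the amine on the chain, since the earlier step concerned only the group on the aromatic nitrogen. No measurement on hand explains this result.

From the compounds shown here alone, whether a morpholine ring, an open-chain dimethylamine or a longer chain would read the same remains open. So does whether 4-methylpiperidin-1-yl behaves alike when paired with the 4-nitrophenyl group of compound 2.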